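Replacing Bromo with Methoxy: an Expected Paw-Edema Read-out

A few compounds are considered here, and "the series" means these few. Any claim that something is new, unique, unknown or untested is made for them only; others in the source may bear on it.

Compound 1 `Cc1cc2nn(-c3ccc(Cl)cc3)c(C)c2c(=O)o1` gives 38.2% in a functional assay on the whole organism for inhibition, with Rattus norvegicus as the target, read by paw edema, with a stated time of 4 h, at a dose of 50 mg/kg; a lower number here means less inhibition, a higher number more inhibition at the dose given (going by the name of the read-out).
Compound 2 `Cc1cc2nn(-c3ccc(Br)cc3)c(C)c2c(=O)o1` gives 38.2% in this assay.

For the measured compounds named here, only one step connects the measured pair: no change at the digits printed from compound 1 to compound 2 (within the scatter). Compound 2 therefore stands level with compound 1 on these numbers, and nothing here separates the two.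

Compound 3 `COc1ccc(-n2nc3cc(C)oc(=O)c3c2C)cc1` is the next, unmeasured, compound. Relative to compound 2 the change is methoxy in place of bromo on an aromatic carbon. Going by the values given here, no measured step exchanges a halogen for methoxy; the only step available, a swap of one halogen for another, stayed within the scatter. That step is only a weak guide, so the expected step for compound 3 in this assay is none beyond the scatter, namely a number 2.2 percentage points lower from compound 2 to compound 3 (within the scatter), with a wider band than usual. Compound 3 is therefore estimated to give 36% in this assay, within a range from 20% to 52%.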

Compound 3, a percentage reported as inhibition, in the whole organism at one dose (the size of the read-out at that dose, not a potency): 42.2%
The estimate for compound 3 lay 6.2 percentage points below the measured number, and the stated range covers the measured number.
By their numbers in this assay, from the lowest: compounds 1, 2 and 3 (each within the scatter of the next).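

At this place on the six-membered aromatic ring, para to a large group, the earlier pair had exchanged only one halogen for another, whereas methoxy is a group of a different kind. In this assay, methoxy in place of bromo gives a number 4 percentage points higher from compound 2 to compound 3 (within the scatter), and methoxy in place of chloro gives a number 4 percentage points higher from compound 1 to compound 3 (within the scatter), so two heavy atoms including a hydrogen-bond acceptor can replace a single halogen atom without a step beyond the scatter. No available evidence explains this outcome.

From the compounds shown here alone, whether an amine, a carboxylic acid or a longer chain at this place would move the read-out beyond the scatter remains open. Also open, going by these compounds, is whether the same holds at other doses or times, since these values describe a single dose and time and give no potency.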